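Swapping ethoxy for trifluoromethyl on a quinoline amide core

The source may hold more compounds than are shown below. What is called first, only, known or untested is meant among the compounds shown, and "the series" means these compounds.

Compound 1 `Cc1c(C(=O)Nc2c(F)cc(-c3cccc(F)c3)cc2F)nc2ccc(C(F)(F)F)cc2c1O` — 9.37%
Compound 2 `CCOc1ccc2nc(C(=O)Nc3c(F)cc(-c4cccc(F)c4)cc3F)c(C)c(C(=O)O)c2c1` — 3.05%

Both measured compounds were tested in a functional assay on A-375 cells (Homo sapiens) for antiproliferative activity, read by MTT assay, with a stated time of 24 h, tested at 0.14 ug/mL; on this read-out lower numbers stand for a weaker effect and higher numbers for a stronger effect at the one concentration tested. Compound 1 gives 9.37%, and compound 2 gives 3.05%. These two numbers lie within the usual scatter of each other, so no order between compound 1 and compound 2 can be read from them; what the pair shows is that both compounds produce only a small effect at the concentration tested.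

Compound 3 `Cc1c(C(=O)Nc2c(F)cc(-c3cccc(F)c3)cc2F)nc2ccc(C(F)(F)F)cc2c1C(=O)O` has not yet been measured. It differs from compound 2 in one place: trifluoromethyl in place of ethoxy on an aromatic carbon. Among the measured compounds shown here, no measured pair shows this change on its own, so there is no directly comparable step to lean on. Since compound 1 already carries a trifluoromethyl group at this place and gives 9.37%, a small effect seems the most likely outcome.

The step from compound 2 to compound 3 is expected to be a number 3 percentage points higher from compound 2 to compound 3 (within the scatter), within the scatter. In this assay compound 3 is estimated to give 6%, with a likely range from 0% to 15%.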

Compound 3, a percentage reported as inhibition, at one concentration (the size of the read-out at that concentration, not a potency): 2.56%
Compound 3: middle estimate off by 3.4 percentage points, on the high side, and the stated range covers the measured number.
By their numbers in this assay, from the lowest: compounds 3, 2 and 1 (each within the scatter of the next).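

In this assay, trading ethoxy for trifluoromethyl on this aromatic carbon gives a number 0.5 percentage points lower from compound 2 to compound 3 (within the scatter), so with the carboxy group kept in place, these two groups cannot be told apart at this position. Among the compounds shown here, this is the first direct reading of the swap. The earlier compounds shown here differed from each other in more than one place. The other single change, carboxy in place of hydroxy on an aromatic carbon with trifluoromethyl kept in place, gives a number 6.8 percentage points lower from compound 1 to compound 3 (within the scatter), so that swap cannot be told apart from the usual scatter either, and nothing measured here offers an explanation for these results.

All three compounds give only a small effect at the single concentration tested, which leaves it open whether either position can influence this read-out at all. An amine or a longer chain on the ethoxy-bearing carbon, or an amide at the place of the carboxy group, could show whether any group there gives a clearly larger effect than the three compounds shown.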